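The source may hold more compounds than are shown below. What is called first, only, known or untested is meant among the compounds shown, and "the series" means these compounds.

Measured so far in an assay on HepG2 cells for activation of nuclear factor erythroid 2-related factor 2 (Homo sapiens), read by a luciferase reporter, with a stated time of 5 h; a higher number here means that more compound is needed for the effect, a lower number that less compound is needed:
- compound 1 `Fc1ccccc1/C=C/c1ccccc1` gives 700 nM
- compound 2 `Oc1ccc(/C=C/c2ccccc2F)cc1` gives 11400 nM

Within the data shown here, compound 1 has the lowest number of the two; compound 2 is its only neighbour, and the step from one to the other was a 16-fold higher number from compound 1 to compound 2 (1.21 log units; beyond the scatter), a hydroxy in place of hydrogen on an aromatic carbon.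

Compound 3 `Fc1cccc(/C=C/c2ccccc2F)c1` is not yet measured. It differs from compound 1 by fluoro in place of hydrogen on an aromatic carbon. Among the measured compounds shown here, the only measured step concerns a hydroxy, which brings a donor and an acceptor, whereas the entering fluoro brings neither; that step is therefore of limited bearing here, and no direct precedent for a second fluoro exists among the measured compounds. Given that, the expected step of a 1.3-fold higher number from compound 1 to compound 3 (0.11 log units; within the scatter) is small and within the scatter, in no firm direction. Compound 3 is estimated at 900 nM, with a range from 300 nM to 3000 nM.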

Compound 3, half-maximal effective concentration: > 15000 nM
Compound 3: no number, only a limit; the forecaster's own chance of this, stated with the estimate: 5%; at least 16-fold (1.22 log units) between middle value and limit.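

A single fluoro, with 0 hydrogen-bond donors and 0 hydrogen-bond acceptors, placed on an aromatic carbon meta to a group of 9 heavy atoms, is enough for a large step: an at least 21-fold higher number from compound 1 to compound 3 (1.33 log units; beyond the scatter). The earlier step, a 16-fold higher number from compound 1 to compound 2 (1.21 log units; beyond the scatter), involved a hydroxy and could not show that a large rise occurs without a hydrogen-bond donor or acceptor in the entering group. The reading for compound 3 in this assay is a limit and not a number: the limit of > 15000 nM in this assay, at which 1 of the 3 values shown sits.

As far as these compounds go, the full size of the step therefore stays unknown. The compounds shown leave open whether a methoxy, an amine or a carboxylic acid at this same carbon would raise the number as far, or whether any group larger than hydrogen is met with the same rise here.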